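This account rests on a few compounds, and the source may have more. Where it says the series, first, only, none or still open, it means among the compounds named here.

Compound 1 `C=CC[C@H]1C[C@]2(C(C)Cc3ccc(F)cc3)OCOC2=CC1=O`, compound 2 `C=CC[C@H]1C[C@]2([C@@H](C)Cc3ccc(OC)c(C)c3)OCOC2=CC1=O` and compound 3 `C=CC[C@H]1C[C@]2([C@@H](C)Cc3ccc(OC)c(C(=O)NC)c3)OCOC2=CC1=O` share one core and differ only in the aryl part of the side chain. In a functional assay on M14 cells (Homo sapiens) for antiproliferative activity, with a stated time of 72 h (a higher number here means a weaker inhibitor, a lower number a stronger inhibitor), compound 1 gives > 20000 nM, which is a limit of the assay and not a number. In this assay compound 2 gives 410 nM, while compound 3 gives 1400 nM; compound 3 therefore stands at the higher of the two numbers available, with compound 2 as its nearest comparator. Going by the values given here, the step of a 3.4-fold higher number from compound 2 to compound 3 (0.53 log units; beyond the scatter) is the only measured step that touches the substituent in question. Compound 4 `C=CC[C@H]1C[C@]2([C@@H](C)Cc3ccc(OC)c(Cl)c3)OCOC2=CC1=O` is not yet measured; it differs from compound 3 by chloro in place of methylcarbamoyl on an aromatic carbon. Chloro, like the methyl of compound 2, brings no hydrogen-bond donor or acceptor to that position, and compound 2 gives 410 nM in this assay, so compound 4 is expected to move back toward compound 2 rather than past it. The expected step is a 2.8-fold lower number from compound 3 to compound 4 (0.45 log units; beyond the scatter), a modest move to a lower number. For compound 4 the estimate in this assay is 500 nM, with a range from 200 nM to 1300 nM.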

Compound 4, half-maximal inhibitory concentration: 240 nM
Beside the measured number, compound 4's estimate is 2.1-fold (0.32 log units) above it; the measured number falls inside the stated range.
By their numbers in this assay, from the lowest: compounds 4 and 2 (each within the scatter of the next); then compound 3. At a limit, above all of these: compound 1.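

In this assay, chloro in place of methylcarbamoyl on the aromatic carbon ortho to a methoxy group gives a 5.8-fold lower number from compound 3 to compound 4 (0.77 log units; beyond the scatter), so the loss seen with methylcarbamoyl is not a general feature of substitution at this position. Methyl and chloro are not separated here: a 1.7-fold lower number from compound 2 to compound 4 (0.23 log units; within the scatter), which leaves compound 3 as the only one of these three set apart. The data shown give no reason for either step.

Methylcarbamoyl differs from methyl and chloro in both heavy-atom count and hydrogen-bond donors and acceptors, so these compounds cannot show which of these differences matters. A nitrile, a primary amide, an amine or a carboxylic acid at this position would test that, and a bromine atom would show how far the level shared by compound 2 and compound 4 extends.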